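This account rests on a few compounds, and the source may have more. Where it says the series, first, only, none or still open, it means among the compounds named here.

The measured compounds:

Compound 1 `CS/C(=N\C(=O)c1ccccc1)NC(=O)c1ccccc1` gives > 10000 nM in a functional assay on PC-3 cells (Homo sapiens) for cytotoxicity, read by MTT assay (a higher number here means a weaker inhibitor, a lower number a stronger inhibitor), which is a limit of the assay and not a number.

Compound 2 `CC[Se]/C(=N\C(=O)c1ccccc1)NC(=O)c1ccccc1` gives > 10000 nM in this assay, again a limit of the assay.

Among the measured compounds shown here, compound 2 thus stands at the limit, and the single step leading to it, a step that the two limits leave unreadable from compound 1 to compound 2, has no readable size, both of its ends being limits. For the measured compounds named here, the only evidence on the numbers is the limit of > 10000 nM in this assay, at which 2 of the 2 values shown sit.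

Compound 3 `CC(C)[Se]/C(=N\C(=O)c1ccccc1)NC(=O)c1ccccc1` differs from compound 2 by methyl in place of hydrogen on a saturated chain carbon bound to a saturated chain carbon and a selenium atom. Going by the values given here, the one measured step, a step that the two limits leave unreadable from compound 1 to compound 2, also changes the group on the carbon with the double bond to nitrogen, yet it gives no size and no direction to build on. No step beyond the scatter is therefore expected in this assay. Compound 3 is expected to give about 20000 nM in this assay, estimated between 8000 nM and 60000 nM, most probably reported as a limit once more. The estimated step that the limit leaves unreadable from compound 2 to compound 3 is expected to stay within the scatter.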

Compound 3, half-maximal inhibitory concentration: > 10000 nM
Compound 3 was reported as a limit (the forecaster's own chance of this, stated with the estimate: 85%); the middle value does not contradict the limit.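

No new step can be read: compound 3, like compound 2 and compound 1, is reported only as a limit of the assay. The compounds shown leave open how far each lies beyond that limit in this assay, and whether changing the group on the carbon with the double bond to nitrogen alters the value at all.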